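The compounds below may be only part of what the source reports. "The series", "measured", "known", "first", "only" and "open" are said of these compounds alone.

Of the compounds shown here, three that share one core have been measured in an ADME assay on microsomes from liver (Homo sapiens) for metabolic stability, read by LC-MS, using NADPH, tested at 5 uM; on this read-out lower numbers stand for a shorter-lived compound and higher numbers for a longer-lived compound. Compound 1 `Cc1cccc(CSc2cc(Cl)c(C)cc2S(=O)(=O)/N=C(\N)n2nccc2-c2ccccc2)c1` gives 0.232 h in this assay; among the three numbers, compound 1 has the highest, but its neighbours sit so close that no order can be read from them. Compound 3 `Cc1cccc(CSc2cc(Cl)c(C)cc2S(=O)(=O)/N=C(\N)n2nc(C)cc2-c2ccccc2)c1` gives 0.214 h, and the change a 1.1-fold lower number from compound 1 to compound 3 (0.04 log units; within the scatter) lies within the scatter. Compound 2 `Cc1cc(-c2ccccc2)n(/C(N)=N/S(=O)(=O)c2cc(C)c(Cl)cc2SCc2cccc(Cl)c2)n1` gives 0.205 h, and the change a 1.0-fold higher number from compound 2 to compound 3 (0.02 log units; within the scatter) also lies within the scatter; the values of compound 1 and compound 2 are likewise close to each other.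

Compound 4 `Cc1cc(S(=O)(=O)/N=C(\N)n2nccc2-c2ccccc2)c(SCc2ccccc2C(F)(F)F)cc1Cl` has not yet been measured in this assay. It differs from compound 1 in one place: 2-(trifluoromethyl)phenyl in place of 3-methylphenyl on a saturated chain carbon bound to a sulfur. Neither measured step touches this part of the molecule, and both were within the scatter, so the data give no reason to expect a step beyond the scatter in this assay. On that basis compound 4 is expected to give about 0.22 h, with a range from 0.11 h to 0.45 h. This estimate means a step of a 1.1-fold lower number from compound 1 to compound 4 (0.02 log units; within the scatter), which is expected to stay within the scatter.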

Compound 4, half-life: 0.15 h
Beside the measured number, compound 4's estimate is 1.5-fold (0.17 log units) above it; the range from low to high includes it.
By their numbers in this assay, from the lowest: compounds 4, 2, 3 and 1 (each within the scatter of the next).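

Within the data shown here, this is the first look at the group on the saturated chain carbon bound to a sulfur, which neither earlier step touched. In this assay, replacing 3-methylphenyl with 2-(trifluoromethyl)phenyl gives a step (a 1.5-fold lower number from compound 1 to compound 4 (0.19 log units; within the scatter)), so this place, like the two changes seen earlier, has not yet produced a step beyond the scatter. The swap alters both the group and its place on the phenyl ring, and nothing shown bears on what lies behind the number.

Going by these compounds, it remains open whether 2-methylphenyl or 3-(trifluoromethyl)phenyl would read like compound 1 or compound 4, which would pull those two differences apart. Also open, on these data alone, is whether an amine, a carboxylic acid or a longer chain bound to the sulfur would move the half-life beyond the scatter.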